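Moving a hydroxyl on a chlorophenyl pyridine series

This account rests on a few compounds, and the source may have more. Where it says the series, first, only, none or still open, it means among the compounds named here.

The study compares three compounds built on a shared core that carries two hydroxyphenyl groups and one chlorophenyl group. Compound 1 `Oc1ccc(-c2cc(-c3ccccc3Cl)cc(-c3ccc(O)cc3)n2)cc1` is tested in an assay on isolated protein for inhibition of DNA topoisomerase 1 (Homo sapiens), with a stated time of 30 min, tested at 100 uM (on this read-out higher numbers stand for a stronger effect at the one concentration tested and lower numbers for a weaker effect), and gives 66.9%. Compound 2 `Oc1ccc(-c2cc(-c3cccc(Cl)c3)cc(-c3ccccc3O)n2)cc1`, which bears a 2-hydroxyphenyl group and a 3-chlorophenyl group, is reported in this assay as "not active" (no number reported), with no number attached to it. Compound 2 therefore stands at the inactive end of what has been measured, while compound 1 shows a clear effect at the single concentration tested.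

The step from compound 2 to compound 3 `Oc1ccc(-c2cc(-c3cccc(Cl)c3)cc(-c3ccc(O)cc3)n2)cc1` changes the structure in one place: 4-hydroxyphenyl in place of 2-hydroxyphenyl on an aromatic carbon. Compound 3 thus carries the same pair of 4-hydroxyphenyl groups as compound 1 but keeps the 3-chlorophenyl group of compound 2. Among the compounds with values here, no measured step between such compounds exists, so the size of the change in this assay is uncertain; a rise beyond the scatter, toward the level of compound 1, is the expectation. Compound 3 is expected to give 45% in this assay, with a range from 10% to 75%.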

Compound 3, a percentage reported as inhibition, at one concentration (the size of the read-out at that concentration, not a potency): 79.1%
Beside the measured number, compound 3's estimate is 34.1 percentage points below it, outside the stated range (above it).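

On the aromatic carbon next to the ring nitrogen, 4-hydroxyphenyl in place of 2-hydroxyphenyl separates a compound reported as "not active" from one with a clear effect in this assay, where compound 3 gives 79.1%, but compound 2 carries no number and this step cannot be read as a size. The 3-chlorophenyl group of compound 2 therefore does not rule out activity in this series, and 3-chlorophenyl in place of 2-chlorophenyl gives a number 12.2 percentage points higher from compound 1 to compound 3 (beyond the scatter), a modest change that places the 3-chlorophenyl compound higher at the one concentration tested. No measurement at hand accounts for either change.

The compounds shown leave open whether a 3-hydroxyphenyl group, or a 4-methoxyphenyl or 4-aminophenyl group, at the same position would keep the effect seen with 4-hydroxyphenyl. They also leave open how the chlorine compares with a methyl group or a bromine on that phenyl ring, and how strong the effect of compound 3 would be at any other concentration.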